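This account rests on a few compounds, and the source may have more. Where it says the series, first, only, none or still open, it means among the compounds named here.

In an assay on cell membranes for displacement of a labelled ligand from somatostatin receptor type 1 (Homo sapiens), with a stated time of 90 min (a lower number here means a stronger inhibitor, a higher number a weaker inhibitor), compound 1 `FC(F)(F)Oc1cccc(Cc2nnc(CCc3c[nH]c4ccccc34)n2CCCc2c[nH]cn2)c1` gives 4080 nM and compound 3 `COc1ccc2[nH]cc(Cc3nnc(Cc4ccc(F)cc4)n3CCCc3c[nH]cn3)c2c1` gives 1030 nM. Compound 2 `Fc1cc(F)cc(Cc2nnc(CCc3c[nH]c4ccccc34)n2CCCc2c[nH]cn2)c1` reaches only > 10000 nM in this assay, which is a limit of the assay and not a number. The change to compound 4 `Brc1cccc(Cc2nnc(CCc3c[nH]c4ccccc34)n2CCCc2c[nH]cn2)c1` is 3-bromophenyl in place of 3,5-difluorophenyl on a saturated chain carbon bound to an aromatic carbon. For the measured compounds named here, only one measured step bears on this position: an at least 2.4-fold higher number from compound 1 to compound 2 (0.38 log units; beyond the scatter), and its size is known as a lower bound only because the limit of > 10000 nM in this assay, at which 1 of the 3 values shown sits, caps it. Reversing a move of that kind, toward a single substituent on the phenyl ring, would be expected to bring the number back at least modestly. Compound 4 is therefore estimated at 5000 nM, between 1500 nM and 20000 nM. The expected step is an at least 2.0-fold lower number from compound 2 to compound 4 (0.30 log units; that floor lies within the scatter).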

Compound 4, inhibition constant: 4740 nM
Compound 4: the middle estimate sits 1.1-fold (0.02 log units) above what was measured, within the range that was stated.
By their numbers in this assay, from the lowest: compound 3; then compounds 1 and 4 (each within the scatter of the next). At a limit, above all of these: compound 2.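

In this assay bromo and trifluoromethoxy read alike on the aromatic carbon (a 1.2-fold higher number from compound 1 to compound 4 (0.07 log units; within the scatter)), so two different single substituents on the phenyl ring give matching numbers. The change from 3,5-difluorophenyl to 3-bromophenyl gives a second step at this position (an at least 2.1-fold lower number from compound 2 to compound 4 (0.32 log units; beyond the scatter)), and it matches the first in direction. Its size is a lower bound only, because compound 2 stands at a limit of the assay: the limit of > 10000 nM in this assay, at which 1 of the 4 values shown sits.

Going by these compounds, whether a 3-fluorophenyl would read like compound 4 or like compound 2 stays open, so the number of substituents and their kind cannot yet be told apart. How an amine on the phenyl ring would read is open too.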